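Changing one aromatic group on a highly potent compound

This account rests on a few compounds, and the source may have more. Where it says the series, first, only, none or still open, it means among the compounds named here.

Compound 1 `COc1ccc(-c2cccc(=O)n2-c2cc(OC)c(OC)c(OC)c2)cc1` is the starting point in a functional assay on HepG2 cells (Homo sapiens) for cytotoxicity, read by spectrophotometry, with a stated time of 72 h; a higher number here means a weaker inhibitor, a lower number a stronger inhibitor. In this assay compound 1 gives < 10 nM, which is a limit of the assay and not a number. Compound 2 `COc1ccc(-c2cccc(=O)n2-c2cc(OC)c(OC)c(OC)c2)cc1OC` carries a methoxy in place of hydrogen on an aromatic carbon of the 4-methoxyphenyl group and gives 513 nM. That single change is an at least 51-fold higher number from compound 1 to compound 2 (1.71 log units; beyond the scatter).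

Compound 3 `COc1cc(-n2c(-c3cccc(O)c3)cccc2=O)cc(OC)c1OC` has 3-hydroxyphenyl in place of 4-methoxyphenyl on an aromatic carbon. Among the compounds with values here, only one measured step bears on this change, and it alters the same group. Given an at least 51-fold higher number from compound 1 to compound 2 (1.71 log units; beyond the scatter), a clear weakening is expected here too, though its size is uncertain from a single step. The expected size is an at least 40-fold higher number from compound 1 to compound 3 (1.60 log units; beyond the scatter). The estimate for compound 3 is 400 nM, with an expected range from 50 nM to 3000 nM.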

Compound 3, half-maximal inhibitory concentration: 34 nM
The estimate for compound 3 lay 12-fold (1.07 log units) above the measured number, and the stated range ends above it.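

In this assay, exchanging the 4-methoxyphenyl group for 3-hydroxyphenyl still weakens the compound, with an at least 3.4-fold higher number from compound 1 to compound 3 (0.53 log units; beyond the scatter). Compound 2 gives 513 nM and compound 3 gives 34 nM, so a change to this aromatic group need not cost as much as the added methoxy did, and a group with a hydrogen-bond donor can stand here while the number stays well below that of compound 2. The full size of the step from compound 1 remains unknown because its value is a limit of the assay and not a number: the limit of < 10 nM in this assay, at which 1 of the 3 values shown sits.

The compounds shown do not separate the two parts of this change, the place of the oxygen on the ring and hydroxy against methoxy. Also open, on these data alone, is how an amine or a carboxylic acid on this aromatic ring would fare.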